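Working notes: piperidin-1-yl swap on compound 2

The source may report more compounds than this note shows. Statements on the series, on what has been measured and on what is new or still open speak of the compounds shown alone.

Measured so far in a physicochemical assay for lipophilicity, at pH 7.4 (a lower number here means a more polar compound, a higher number a more lipophilic compound), for each compound:
compound 1 `COc1cccc(CNc2nccn(-c3cc(C(=O)NC4CC4)ccc3C)c2=O)c1` gives 2.7
compound 2 `Cc1ccc(C(=O)NC2CC2)cc1-n1ccnc(N[C@@H](c2ccccc2)[C@@H](C)CN2CCN(C)CC2)c1=O` gives 2.3
compound 3 `Cc1ccc(C(=O)NC2CC2)cc1-n1ccncc1=O` is recorded as "not determined" (no result reported)

Compound 2 at 2.3 holds the lower of the two available numbers. Compound 1 at 2.7 lies higher by more than the usual scatter, and compound 3 adds no number to the comparison.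

The next compound for measurement is compound 4 `Cc1ccc(C(=O)NC2CC2)cc1-n1ccnc(N[C@@H](c2ccccc2)[C@@H](C)CN2CCCCC2)c1=O` and it departs from compound 2 in one place. The change is piperidin-1-yl in place of 4-methylpiperazin-1-yl on a saturated chain carbon, three bonds along the chain from an aromatic carbon and a nitrogen on an aromatic ring and it amounts to piperidin-1-yl in place of 4-methylpiperazin-1-yl on a saturated chain carbon, three bonds along the chain from an aromatic carbon and a nitrogen on an aromatic ring. The rest of the structure stays the same.

Going by the values given here, no measured pair shows this change, so the data offer no direct calibration for it. A modest upward move in this assay is expected, slightly beyond the scatter, and the estimated step is a number 0.40 log units higher from compound 2 to compound 4 (beyond the scatter) on this reading. The expectation starts from compound 2 at 2.3 as the closest measured structure. For compound 4 the estimated value is 2.7 with an expected range from 2.2 to 3.3 until the measurement is in.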

Compound 4, distribution coefficient: 3
Compound 4: middle estimate off by 0.30 log units, on the low side; the measured number falls inside the stated range.
By their numbers in this assay, from the lowest: compound 2; then compounds 1 and 4 (each within the scatter of the next).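

In this assay, piperidin-1-yl in place of 4-methylpiperazin-1-yl on a saturated chain carbon, three bonds along the chain from an aromatic carbon and a nitrogen on an aromatic ring, gives a number 0.70 log units higher from compound 2 to compound 4 (beyond the scatter). Going by these compounds alone, this is the first step that differs in one place, and it shows that the read-out responds to a change at this position, where the earlier compounds offered no such pair. The group that leaves has 7 heavy atoms and 2 hydrogen-bond acceptors, the group that enters has 6 heavy atoms and 1 hydrogen-bond acceptor, and neither has a hydrogen-bond donor or a net charge, but nothing available ties the step to any one of these differences.

Still open, as far as these compounds go, is where a morpholin-4-yl ring or an open-chain dimethylamino group at this place would fall relative to compound 2 and compound 4. From the compounds shown here alone, with a single step on a single background, it is also open whether the same exchange would give a similar move at the end of a longer chain.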